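The source may report more compounds than this note shows. Statements on the series, on what has been measured and on what is new or still open speak of the compounds shown alone.

Of the compounds shown here, three have been measured in an ADME assay on Huh-7 cells (Homo sapiens) for cytotoxicity; a lower number here means that less compound is tolerated, a higher number that more compound is tolerated. Compound 1 `NC(=S)N1CCCc2c(OCCCCCOc3cccc4ccccc34)cccc21` stands at a limit of the assay, giving > 50000 nM. Compound 2 `O=C(NC(=S)N1CCc2c(OCc3ccccc3)cccc21)c1ccccc1` likewise stands at a limit, giving > 50000 nM. Compound 3 `N#Cc1cccc(C(=O)NC(=S)N2CCc3c(OCCCCCOc4ccc(Cl)cc4)cccc32)c1` is the only one of the three with a reported number, giving 9750 nM in this assay. The other two values sit together at the limit of > 50000 nM in this assay, at which 2 of the 3 values shown sit, so compound 3 is the sole point in this assay from which a half-maximal cytotoxic concentration can be read directly.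

Compound 4 `COc1ccc(C(=O)NC(=S)N2CCc3c(OCCCCCOc4ccc(Cl)cc4)cccc32)cc1` has not yet been measured. It differs from compound 3 in a single place: 4-methoxyphenyl in place of 3-cyanophenyl on a carbonyl carbon. No pair of measured compounds that differ in one place is available, so the size of this step has no precedent among the numbers shown. The step of a 1.5-fold higher number from compound 3 to compound 4 (0.19 log units; within the scatter) is expected to stay within the usual scatter of this assay, in either direction, and a reading that ends at a limit rather than a number is considered reasonably likely. For compound 4 the estimated half-maximal cytotoxic concentration is 15000 nM, with a range from 5000 nM to 50000 nM.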

Compound 4, half-maximal cytotoxic concentration: 34400 nM
For compound 4 the middle estimate is 2.3-fold (0.36 log units) below the measured one, within the range that was stated.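

In this assay, among the compounds shown here, replacing 3-cyanophenyl with 4-methoxyphenyl on a carbonyl carbon gives a 3.5-fold higher number from compound 3 to compound 4 (0.55 log units; beyond the scatter), the first comparison between compounds that differ in one place. This shows that the reading responds to this position even though the two groups match in heavy atoms, hydrogen-bond donors and hydrogen-bond acceptors, so those counts do not separate them. Compound 1 and compound 2 offer no such reading of this position, since each differs from the others in more than one place and each stands at a limit of the assay rather than at a number: the limit of > 50000 nM in this assay, at which 2 of the 4 values shown sit.

From the compounds shown here alone, this single step changes both the substituent and its place on the ring, so it remains open whether the nitrile and methoxy groups themselves or their positions account for the difference, which a 3-methoxyphenyl or a 4-cyanophenyl group on the same carbonyl carbon could separate. Going by these compounds, it also remains open how far the reading would move with a carboxylic acid or an amine on that ring, and whether any such group would carry it to the limit.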